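The source may report more compounds than this note shows. Statements on the series, on what has been measured and on what is new or still open speak of the compounds shown alone.

In a functional assay on thoracic aorta (Rattus norvegicus, strain Wistar), with a stated time of 15 min (a lower number here means that less compound is needed, a higher number that more compound is needed for the effect), compound 3 `CCOc1ccc(Br)cc1C(C)NC(=O)NS(=O)(=O)c1ccc(Cl)cc1`, which carries a bromo group, gives 171000 nM. This is the higher of the two exact numbers available. Compound 2 `CCOc1ccc(Cl)cc1C(C)NC(=O)N(C)S(=O)(=O)c1ccc(Cl)cc1` gives 14600 nM, a lower number by more than the usual scatter.

The next compound to be tested is compound 4 `CCOc1ccc(Cl)cc1C(C)NC(=O)NS(=O)(=O)c1ccc(Cl)cc1`, with chloro in place of bromo on an aromatic carbon. This carbon is para to an ethoxy group. The swap is small, and the rest of compound 3 stays the same.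

Compound 1 `CCOc1ccc(F)cc1C(C)NC(=O)NS(=O)(=O)c1ccc(Cl)cc1`, with fluoro on that carbon, gives only a limit of the assay, > 300000 nM. For the measured compounds named here, the one measured step at this place is therefore an at least 1.7-fold lower number from compound 1 to compound 3 (0.24 log units; that floor lies within the scatter). It offers little guidance on size or direction, so no clear shift is expected in this assay.

The estimate amounts to a 1.2-fold lower number from compound 3 to compound 4 (0.09 log units; within the scatter), an expected step that stays within the scatter. For compound 4 the expected value is 140000 nM, with an estimated range from 60000 nM to 300000 nM.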

Compound 4, half-maximal effective concentration: 281000 nM
Estimate against measurement, compound 4: 2.0-fold (0.30 log units) below, and the stated range covers the measured number.
By their numbers in this assay, from the lowest: compound 2; then compounds 3 and 4 (each within the scatter of the next). At a limit, above all of these: compound 1.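

In this assay, chloro in place of bromo on this aromatic carbon, para to the ethoxy group, makes no clear difference: a 1.6-fold higher number from compound 3 to compound 4 (0.22 log units; within the scatter). With compound 4 in hand, the methyl group on the amide-type nitrogen can also be judged on its own, and hydrogen in its place gives a far larger change than the halogen swap: a 19-fold higher number from compound 2 to compound 4 (1.28 log units; beyond the scatter). Compound 1 gives > 300000 nM, which is a limit of the assay. Chloro in place of fluoro on the aromatic carbon gives an at least 1.0-fold lower number from compound 1 to compound 4 (0.02 log units; that floor lies within the scatter), and this floor shows no clear change.

As far as these compounds go, it remains open whether methyl on that nitrogen would have the same effect with bromo on the aromatic carbon, as this rests on a single pair. Also open, from the compounds shown here alone, is how a longer chain such as ethyl on that nitrogen, or an amine on the aromatic carbon, would behave.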